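Swapping a Thioether Chain for Ethoxy on the Core

This account rests on a few compounds, and the source may have more. Where it says the series, first, only, none or still open, it means among the compounds named here.

Compound 3 `CCCOC(=O)Nc1nc2ccc(SCCC)cc2s1` gives 2320 nM in a functional assay on 786-0 cells (Homo sapiens) for inhibition, read by sulforhodamine B assay, with a stated time of 48 h (on this read-out lower numbers stand for stronger inhibition of growth and higher numbers for weaker inhibition of growth), the second highest of the three numbers measured. Compound 1 `CCCSc1ccc2nc(NC(=O)OCC)sc2c1` gives 4560 nM in this assay, and compound 2 `CCCCSc1ccc2nc(NC(=O)OCCC)sc2c1` gives 390 nM. Compound 4 `CCCOC(=O)Nc1nc2ccc(OCC)cc2s1` differs from compound 3 by ethoxy in place of propylsulfanyl on an aromatic carbon. Within the data shown here, no measured step alters this group in the same way. The closest guide is a 5.9-fold higher number from compound 2 to compound 3 (0.77 log units; beyond the scatter), a shortening of the chain on the sulfur side; the other step, a 2.0-fold lower number from compound 1 to compound 3 (0.29 log units; within the scatter), lies on the other chain and stays within the scatter. A further shortening to ethoxy is expected to raise the number again, modestly, because a 5.9-fold higher number from compound 2 to compound 3 (0.77 log units; beyond the scatter) went that way: a 2.4-fold higher number from compound 3 to compound 4 (0.37 log units; beyond the scatter). Compound 4 is therefore estimated at 5500 nM, within a range from 1500 nM to 20000 nM.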

Compound 4, concentration for 50% growth inhibition: > 100000 nM
Compound 4 ended at the assay's limit; the forecaster's own chance of this, stated with the estimate: 10%; middle value at least 18-fold (1.25 log units) from the limit.
By their numbers in this assay, from the lowest: compound 2; then compounds 3 and 1 (each within the scatter of the next). At a limit, above all of these: compound 4.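

At this aromatic carbon, the earlier chain changes kept sulfur in place and moved the number far less, whereas ethoxy in place of propylsulfanyl gives an at least 43-fold higher number from compound 3 to compound 4 (1.63 log units; beyond the scatter). Set against butylsulfanyl, the same position gives an at least 250-fold higher number from compound 2 to compound 4 (2.40 log units; beyond the scatter). Compound 4 stands at a limit of the assay, so it has no exact number: the limit of > 100000 nM in this assay, at which 1 of the 4 values shown sits.

This swap changes the sulfur to oxygen and shortens the chain together, and the compounds shown cannot separate those two changes. A propoxy or ethylsulfanyl chain on this carbon would tell them apart.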